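Proline and leucine amides of a chloropurine: alanine analogue

A few compounds are considered here, and "the series" means these few. Any claim that something is new, unique, unknown or untested is made for them only; others in the source may bear on it.

Measured compounds:
compound 1 `O=C(O)[C@@H]1CCCN1C(=O)CN(c1nc(Cl)nc2[nH]cnc12)C1CC1` gives 7.29%
compound 2 `CC(C)C[C@H](NC(=O)CN(c1nc(Cl)nc2[nH]cnc12)C1CC1)C(=O)O` gives 9.13%

Both compounds were tested in a functional assay on the whole organism (Tail, strain ICR) with Mus musculus as the target, in the tail flick test, with a stated time of 150 min, at a dose of 25 umol/kg by the oral route; on this read-out higher numbers stand for a stronger effect at the one dose given and lower numbers for a weaker effect. Compound 2 gives 9.13%, the upper of the two numbers, but the gap to compound 1, which gives 7.29%, lies within the usual scatter, so the two read-outs are treated as equal. Within the data shown here, no step between measured compounds that differ in one place is available in this set.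

Compound 3 `C[C@H](NC(=O)CN(c1nc(Cl)nc2[nH]cnc12)C1CC1)C(=O)O` is the alanine counterpart of compound 2. The change from compound 2 to compound 3 is hydrogen in place of isopropyl on a saturated chain carbon, two bonds along the chain from an amide-type nitrogen and a carbonyl carbon.

With both measured numbers in the same low region, no basis exists for a step beyond the scatter in either direction. The step from compound 2 to compound 3 in this assay is expected to be a number 1.1 percentage points lower from compound 2 to compound 3 (within the scatter), no larger than the scatter. Compound 3 is estimated at 8%, with a range from 0% to 20%.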

Compound 3, a percentage reported as activity, at one dose (the size of the read-out at that dose, not a potency): 14.7%
Compound 3: middle estimate off by 6.7 percentage points, on the low side; the measured number falls inside the stated range.
By their numbers in this assay, from the lowest: compounds 1, 2 and 3 (each within the scatter of the next).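

In this assay, hydrogen in place of isopropyl on a saturated chain carbon, two bonds along the chain from an amide-type nitrogen and a carbonyl carbon, gives a number 5.6 percentage points higher from compound 2 to compound 3 (within the scatter), so the isopropyl can go without a change beyond the scatter at this one dose. (1-Carboxyethyl)amino in place of 2-carboxypyrrolidin-1-yl on a carbonyl carbon gives a number 7.4 percentage points higher from compound 1 to compound 3 (within the scatter), so this change also stays inside the scatter, and the three read-outs cannot be told apart. No independent measurement bears on these steps.

From the compounds shown here alone, whether a benzyl group or an aminobutyl chain on the same chain carbon would give a step beyond the scatter remains open. So does the effect of a methyl ester or primary amide in place of the carboxylic acid shared by all three compounds.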